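A Methyl Step Expected to Stay Within the Scatter

This account rests on a few compounds, and the source may have more. Where it says the series, first, only, none or still open, it means among the compounds named here.

Of the compounds shown here, three built on one shared core have been measured in a functional assay on DU-145 cells (Homo sapiens) for cytotoxicity, read by MTT assay, with a stated time of 48 h; on this read-out lower numbers stand for stronger inhibition and higher numbers for weaker inhibition. Compound 1 `CCOC(=O)c1c(-c2cc3ccccc3oc2=O)nn(-c2ccccc2)c1C(=O)OCC` gives 57000 nM. Compound 2 `CCOC(=O)c1c(-c2cc3ccccc3oc2=O)nn(-c2cccc(C)c2)c1C(=O)OCC`, which carries a methyl in place of hydrogen on an aromatic carbon, gives 47000 nM; that change is a 1.2-fold lower number from compound 1 to compound 2 (0.08 log units; within the scatter). Compound 3 `CCOC(=O)c1c(-c2cc3cc(OC)ccc3oc2=O)nn(-c2ccccc2)c1C(=O)OCC`, which carries a methoxy in place of hydrogen on an aromatic carbon, gives 27000 nM, the lowest of the three numbers; its step from the parent is a 2.1-fold lower number from compound 1 to compound 3 (0.32 log units; beyond the scatter), whereas the values of compound 2 and compound 3 lie within the scatter of each other.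

Compound 4 `CCOC(=O)c1c(-c2cc3cc(OC)ccc3oc2=O)nn(-c2cccc(C)c2)c1C(=O)OCC` differs from compound 3 by methyl in place of hydrogen on an aromatic carbon. For the measured compounds named here, the only measured step of this kind, a 1.2-fold lower number from compound 1 to compound 2 (0.08 log units; within the scatter), stayed within the scatter, so no step beyond the scatter is expected in this assay here either. Compound 4 is therefore expected to give about 23000 nM, with a range from 11000 nM to 48000 nM. The expected step is a 1.2-fold lower number from compound 3 to compound 4 (0.07 log units; within the scatter).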

Compound 4, half-maximal inhibitory concentration: 31000 nM
Estimate against measurement, compound 4: 1.3-fold (0.13 log units) below, and the stated range covers the measured number.
By their numbers in this assay, from the lowest: compounds 3, 4, 2 and 1 (each within the scatter of the next, the first and the last beyond it).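

In this assay, the change from phenyl to 3-methylphenyl now has a second reading on the methoxy-bearing core, a 1.1-fold higher number from compound 3 to compound 4 (0.06 log units; within the scatter), and the two readings of this change agree: the same change on two cores in this assay, a 1.2-fold lower number (0.08 log units; within the scatter) from compound 1 to compound 2 and a 1.1-fold higher number (0.06 log units; within the scatter) from compound 3 to compound 4, 1.4-fold (0.14 log units) apart, within the scatter of two such steps. The methoxy change can now also be read with the methyl present, a 1.5-fold lower number from compound 2 to compound 4 (0.18 log units; within the scatter); this step lies within the scatter, whereas the step without the methyl lay beyond it, yet the two steps do not differ beyond the scatter: the same change on two cores in this assay, a 2.1-fold lower number (0.32 log units; beyond the scatter) from compound 1 to compound 3 and a 1.5-fold lower number (0.18 log units; within the scatter) from compound 2 to compound 4, 1.4-fold (0.14 log units) apart, within the scatter of two such steps. Compound 4 therefore gives no sign that the two changes depend on each other in this assay.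

Methyl is the only group shown at this place on the phenyl ring, so these compounds leave open whether an amine, a carboxylic acid or a longer chain there would give a step beyond the scatter.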